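The compounds below may be only part of what the source reports. "The series", "measured", "known", "first", "only" and "open" are said of these compounds alone.

Measured compounds:
compound 1, `CCCc1nccn1CCC(C(N)=O)(c1ccccc1)c1ccccc1`, in an assay on ileum with muscarinic acetylcholine receptor M3 (Cavia porcellus) as the target (a higher number here means a weaker inhibitor, a lower number a stronger inhibitor), compound 1 gives 177 nM;
compound 2, `Cc1cn(CCC(C(N)=O)(c2ccccc2)c2ccccc2)cn1`, in this assay compound 2 gives 10.1 nM.

Compound 2 has the lowest number of the two, and the step of an 18-fold lower number from compound 1 to compound 2 (1.24 log units; beyond the scatter) is large. Compound 3, `Cc1cncn1CCC(C(N)=O)(c1ccccc1)c1ccccc1`, differs from compound 2 by 5-methyl-1H-imidazol-1-yl in place of 4-methyl-1H-imidazol-1-yl on a saturated chain carbon, three bonds along the chain from two aromatic carbons and a carbonyl carbon. No measured step tells how a methyl moved on the same ring behaves; the only step shown, an 18-fold lower number from compound 1 to compound 2 (1.24 log units; beyond the scatter), shows that the substitution pattern of the imidazole can matter greatly, so some shift is plausible. Compound 3 is therefore expected at 30 nM, in the range 8 nM to 120 nM, a step of a 3.0-fold higher number from compound 2 to compound 3 (0.47 log units; beyond the scatter).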

Compound 3, antagonist equilibrium constant: 0.86 nM
Compound 3: middle estimate off by 35-fold (1.54 log units), on the high side; the measured number lies below the stated range.
By their numbers in this assay, from the lowest: compound 3; then compound 2; then compound 1.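

In this assay moving the methyl around the same ring, with the same atoms joined differently, gives a 12-fold lower number from compound 2 to compound 3 (1.07 log units; beyond the scatter) and shows that the place of a single methyl on the imidazole alone produces a large step. Replacing 2-propyl-1H-imidazol-1-yl with 5-methyl-1H-imidazol-1-yl gives a 210-fold lower number from compound 1 to compound 3 (2.31 log units; beyond the scatter) and is the widest step among these compounds. Nothing available explains the difference between the two methyl isomers. Going by these compounds, whether an ethyl in place of the methyl of 5-methyl-1H-imidazol-1-yl would keep the low number remains open.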